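A few compounds are considered here, and "the series" means these few. Any claim that something is new, unique, unknown or untested is made for them only; others in the source may bear on it.

Going by the values given here, in a functional assay on HL-60 cells (Homo sapiens) for antiproliferative activity, read by CCK-8 assay, with a stated time of 72 h (a lower number here means a stronger inhibitor, a higher number a weaker inhibitor), compound 1 `Cc1cc(Nc2cc(N3CCN(C)CC3)nc(Nc3ccc(S(N)(=O)=O)cc3)n2)n[nH]1` gives 213 nM, the higher of the two numbers measured so far. Compound 2 `Cc1cc(Nc2cc(N3CCN(C)CC3)nc(Nc3ccc([N+](=O)[O-])cc3)n2)n[nH]1` gives 69.8 nM. Compound 3 `Cc1cc(Nc2cc(N3CCN(C)CC3)nc(Nc3ccc(Cl)cc3)n2)n[nH]1` keeps the core of compound 1 but carries chloro in place of sulfamoyl on an aromatic carbon. Among the compounds with values here, one measured step bears on this: nitro in place of sulfamoyl gives a 3.1-fold lower number from compound 1 to compound 2 (0.48 log units; beyond the scatter), which is modest but beyond the scatter. That single step suggests a similar, slightly smaller move toward a lower number, so the expected step is a 2.4-fold lower number from compound 1 to compound 3 (0.37 log units; beyond the scatter). The estimate for compound 3 is 90 nM, with an expected range of 30 nM to 250 nM.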

Compound 3, half-maximal inhibitory concentration: 83.4 nM
Estimate against measurement, compound 3: 1.1-fold (0.03 log units) above; the measured number falls inside the stated range.
By their numbers in this assay, from the lowest: compounds 2 and 3 (each within the scatter of the next); then compound 1.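

Going by these compounds alone, replacing sulfamoyl with chloro on this aromatic carbon, para to a large group, gives a 2.6-fold lower number from compound 1 to compound 3 (0.41 log units; beyond the scatter) in this assay and so shows that nitro is not the only group here with a lower number than sulfamoyl. Chloro and nitro show a 1.2-fold higher number from compound 2 to compound 3 (0.08 log units; within the scatter) and cannot be told apart in this assay at this position. Nothing available explains why sulfamoyl gives the higher number. The compounds shown leave open whether an amine, a methoxy group or a carboxylic acid here would fall with chloro and nitro or with sulfamoyl.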